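The source may hold more compounds than are shown below. What is called first, only, known or untested is meant among the compounds shown, and "the series" means these compounds.

Compound 1 `COc1cc(-c2cnn3cc(OC)c(C(C)(C)O)nc23)ccn1` gives 92%
Compound 2 `COc1cn2ncc(-c3ccnc(OC(C)C)c3)c2nc1-c1cnn(C)c1` gives 50%
Compound 3 `COc1cn2ncc(-c3ccnc(OC(C)(C)C)c3)c2nc1-c1cnn(C)c1` gives 61%

All three numbers come from an ADME assay on microsomes from liver (Rattus norvegicus) for metabolic stability, with a stated time of 60 min, tested at 1 uM (on this read-out lower numbers stand for a less stable compound and higher numbers for a more stable compound), and compound 1 stands highest among them, clear of both others by more than the usual scatter. Compound 4 `COc1cc(-c2cnn3cc(OC)c(N(C)C)nc23)ccn1` keeps the core of compound 1 and carries a single change dimethylamino in place of 1-hydroxy-1-methylethyl on an aromatic carbon that puts dimethylamino in place of 1-hydroxy-1-methylethyl on an aromatic carbon, next to the ring nitrogen and ortho to a methoxy group.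

For the measured compounds named here, no measured pair shows this swap directly. Going by the values given here, the only measured step is a number 11 percentage points higher from compound 2 to compound 3 (beyond the scatter) and it is modest, though beyond the scatter. That step adds a methyl on a saturated chain carbon bound to an oxygen, not at the place changed here, so it gives little guidance on size. Compounds 2 and 3 differ from compound 1 in more than one place, which makes them a loose guide too. Still, compound 1 at 92% leaves little room upward, while compound 2 at 50% and compound 3 at 61% show that related compounds can sit well lower. A fall is therefore expected, estimated as a number 24 percentage points lower from compound 1 to compound 4 (beyond the scatter) with much uncertainty. For compound 4 the expected value is 68% with an estimated range from 40% to 90% around it.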

Compound 4, percent of the compound remaining: 3%
Compound 4: middle estimate off by 65 percentage points, on the high side, and the stated range ends above it.
By their numbers in this assay, from the lowest: compound 4; then compound 2; then compound 3; then compound 1.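

In this assay, placing dimethylamino in place of 1-hydroxy-1-methylethyl on the aromatic carbon next to the ring nitrogen gives a number 89 percentage points lower from compound 1 to compound 4 (beyond the scatter), a large step. For the compounds shown here, the only earlier step between measured compounds, a number 11 percentage points higher from compound 2 to compound 3 (beyond the scatter), was modest and lay at a different place, on a saturated chain carbon, so this is the first sign that the read-out can swing across most of its range with a single change at this position on the core of compound 1. Nothing shown here explains why the number falls so far.

This step removes a group with a hydrogen-bond donor and brings in one without a donor, and it also replaces a carbon attached to the core with a nitrogen, so the compounds shown cannot separate these differences. On these data alone, an isopropyl group at the same aromatic carbon would keep the carbon attachment without the hydroxyl, while a pyrrolidine ring would keep the nitrogen attachment in another shape, and it remains open where either would fall relative to compound 1 and compound 4.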